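This account rests on a few compounds, and the source may have more. Where it says the series, first, only, none or still open, it means among the compounds named here.

Compound 1 `CS(=O)(=O)c1ccc(C(=O)N2CCC(C(=O)N3CCc4ccccc43)CC2)cc1[N+](=O)[O-]` and compound 2 `CC1Cc2ccccc2N1C(=O)C1CCN(C(=O)c2ccc(S(C)(=O)=O)c([N+](=O)[O-])c2)CC1` share one core and differ only by a step that the two limits leave unreadable from compound 1 to compound 2. In an assay on isolated protein for inhibition of thyroid hormone receptor beta (Homo sapiens), read by fluorescence polarization (a higher number here means a weaker inhibitor, a lower number a stronger inhibitor), compound 1 gives no number, only a limit, > 60000 nM. In this assay compound 2 likewise gives only a limit, > 60000 nM. Both readings sit at the limit of > 60000 nM in this assay, at which 2 of the 2 values shown sit, so compound 2 stands at the edge of what this assay can report. Compound 3 `CS(=O)(=O)c1ccc(C(=O)N2CCC(C(=O)N3CCc4ccccc4C3)CC2)cc1[N+](=O)[O-]` carries 1,2,3,4-tetrahydroisoquinolin-2-yl in place of 2-methyl-2,3-dihydro-1H-indol-1-yl on a carbonyl carbon. No measured step bears on this change, since the one step shown is itself unreadable between two limits. The step from compound 2 to compound 3 is therefore expected to be a number no higher from compound 2 to compound 3 (the limit leaves the size open). Compound 3 is estimated at 60000 nM, within 20000 nM to 200000 nM, most likely reported again as a limit.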

Compound 3, half-maximal inhibitory concentration: > 60000 nM
Compound 3 was reported as a limit; the forecaster's own chance of this, stated with the estimate: 80%; the middle value sits exactly at the limit.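

Compound 1, compound 2 and compound 3 all remain limits, so no step among them can be read: the limit of > 60000 nM in this assay, at which 3 of the 3 values shown sit.

The compounds shown leave open whether either change to the shared core alters inhibition in this assay.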